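Working notes: from compound 3 to compound 4

The source may hold more compounds than are shown below. What is called first, only, known or untested is meant among the compounds shown, and "the series" means these compounds.

Measured so far in a functional assay (trachea) with Cavia porcellus as the target; a higher number here means a weaker inhibitor, a lower number a stronger inhibitor
- compound 1 `CCn1nc(-c2cccnc2)c2ccccc2c1=O` gives 1320 nM
- compound 2 `CCCCn1nc(-c2cccnc2)c2ccccc2c1=O` gives 2290 nM
- compound 3 `CC(C)=CCn1nc(-c2cccnc2)c2ccccc2c1=O` gives 1380 nM

All three values lie within the scatter of one another, so no order among them can be claimed. Compound 3 stands with the other two, its steps being a 1.0-fold higher number from compound 1 to compound 3 (0.02 log units; within the scatter) and a 1.7-fold lower number from compound 2 to compound 3 (0.22 log units; within the scatter) in this series.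

Compound 4 `O=c1c2ccccc2c(-c2cccnc2)nn1CC1CCCCC1` has not yet been measured. The change is cyclohexyl in place of 2-methylprop-1-en-1-yl on a saturated chain carbon bound to an aromatic nitrogen, counted as cyclohexyl in place of 2-methylprop-1-en-1-yl on a saturated chain carbon bound to an aromatic nitrogen for this pair. The two steps of compound 3 fall at this same place and stay within the scatter, and a 1.7-fold higher number from compound 1 to compound 2 (0.24 log units; within the scatter) does too, two bonds along the chain. Among the compounds with values here, no measured compound carries a ring at this place, so the expectation is an extrapolation. In this assay no step beyond the scatter is expected. The step expected is a 1.2-fold higher number from compound 3 to compound 4 (0.06 log units; within the scatter) on this estimate. Compound 4 is estimated at 1600 nM with an expected range from 650 nM to 4000 nM for the measurement.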

Compound 4, half-maximal inhibitory concentration: 209 nM
Compound 4: middle estimate off by 7.7-fold (0.88 log units), on the high side, outside the stated range (below it).
By their numbers in this assay, from the lowest: compound 4; then compounds 1, 3 and 2 (each within the scatter of the next).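

At this place, on a saturated chain carbon bound to an aromatic nitrogen, the three open-chain compounds could not be separated in this assay, whereas cyclohexyl stands clear of all of them (a 6.6-fold lower number from compound 3 to compound 4 (0.82 log units; beyond the scatter)), (a 6.3-fold lower number from compound 1 to compound 4 (0.80 log units; beyond the scatter)) and (an 11-fold lower number from compound 2 to compound 4 (1.04 log units; beyond the scatter)). All three steps lie beyond the scatter, so compound 4, the only one of the four with a ring at this place, is the strongest inhibitor shown here. No evidence at hand bears on what lies behind these steps.

The compounds shown leave open whether the ring itself or the larger count of carbon atoms goes with the lower number. On these data alone, how a cyclopentyl ring, a phenyl ring, a longer chain or an amine on the cyclohexyl ring would read at this place also remains open.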